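Sulfonyl substituent variation on the arylacetylene phenoxyacetic acid series

The source may report more compounds than this note shows. Statements on the series, on what has been measured and on what is new or still open speak of the compounds shown alone.

Measured compounds:
compound 1 `Cc1ccc(S(=O)(=O)N(C)CC(C)C)cc1C#Cc1cc(Cl)ccc1OCC(=O)O`: 4.2 nM
compound 2 `CS(=O)(=O)c1ccc(F)c(C#Cc2cc(Cl)ccc2OCC(=O)O)c1`: 3.3 nM
compound 3 `COCCNS(=O)(=O)c1ccc(C)c(C#Cc2cc(Cl)ccc2OCC(=O)O)c1`: 3.6 nM

In an assay on CHO cells for displacement of a labelled ligand from prostaglandin D2 receptor 2 (Homo sapiens), read by scintillation counting (on this read-out higher numbers stand for weaker inhibition and lower numbers for stronger inhibition), compound 3 gives 3.6 nM and stands second of the three numbers, with compound 2 and compound 1 on either side, all within the scatter. The step to compound 4 `Cc1ccc(S(C)(=O)=O)cc1C#Cc1cc(Cl)ccc1OCC(=O)O` changes the group on the sulfonyl sulfur: methyl in place of (2-methoxyethyl)amino on a sulfonyl sulfur. Among the compounds with values here, one measured step bears on this position, a 1.2-fold lower number from compound 1 to compound 3 (0.07 log units; within the scatter), which shows that exchanging amino groups on the sulfonyl sulfur left the number essentially unchanged. Compound 2, which also carries a methyl on the sulfonyl sulfur, gives 3.3 nM, close to compound 3. No step beyond the scatter is therefore expected: compound 4 is estimated at 3.5 nM (range 1.7 nM to 7 nM), meaning an expected step of a 1.0-fold lower number from compound 3 to compound 4 (0.01 log units; within the scatter).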

Compound 4, inhibition constant: 5 nM
For compound 4 the middle estimate is 1.4-fold (0.15 log units) below the measured one; measured number inside the range.
By their numbers in this assay, from the lowest: compounds 2, 3, 1 and 4 (each within the scatter of the next).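

In this assay, methyl on the sulfonyl sulfur is not separated from the amino groups: a 1.4-fold higher number from compound 3 to compound 4 (0.14 log units; within the scatter) and a 1.2-fold higher number from compound 1 to compound 4 (0.08 log units; within the scatter) show that neither (2-methoxyethyl)amino nor isobutyl(methyl)amino is required at this sulfur. Methyl in place of fluoro on an aromatic carbon, a 1.5-fold higher number from compound 2 to compound 4 (0.18 log units; within the scatter), likewise gives no readable change, so both places tolerate these exchanges. No evidence is available to explain this flat picture.

Still open, as far as these compounds go, is whether a carboxylic acid or a longer chain on the sulfonyl sulfur would produce a step beyond the scatter.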